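The source may report more compounds than this note shows. Statements on the series, on what has been measured and on what is new or still open speak of the compounds shown alone.

Of the compounds shown here, three have so far been measured in a functional assay on SK-OV-3 cells (Homo sapiens) for inhibition, read by ELISA, with a stated time of 24 h; a lower number here means a stronger inhibitor of growth, a higher number a weaker inhibitor of growth. Compound 1, `O=C(/C=C/c1ccccc1OC(=O)c1ccccc1)NOC(=O)N1CCOCC1`, gives 12700 nM. Compound 3, `O=C(/C=C/c1ccccc1O)NO`, gives 50400 nM. Compound 2, `CO/N=C/C=C/c1ccccc1OC(=O)c1ccccc1`, gives only a limit of the measurement, > 100000 nM, so for this compound the limit of > 100000 nM in this assay, at which 1 of the 3 values shown sits, is all that is known.

Among the two numbers, compound 1 stands lowest, and the nearest number, that of compound 3, lies beyond the usual scatter above it. Both carry the same core, the acrylohydroxamic acid, and compound 1 has it doubly masked, on the phenol by a benzoyl group and on the hydroxamic oxygen by a (morpholin-4-yl)carbonyl group.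

Compound 4, `O=C(/C=C/c1ccccc1OC(=O)c1ccccc1)NOC(=O)c1ccccc1`, has not yet been measured. It differs from compound 1 in one place: phenyl in place of morpholin-4-yl on a carbonyl carbon. The masking of the hydroxamic oxygen thus changes from ((morpholin-4-yl)carbonyl)oxy to benzoyloxy, while the rest of the molecule is kept. Going by the values given here, no measured pair shows the effect of such a swap, so the expected step of a 1.6-fold lower number from compound 1 to compound 4 (0.20 log units; within the scatter) is small and may well lie within the usual scatter, with a slight lean toward a lower number. Compound 4 is therefore expected to give about 8000 nM, in a range from 2500 nM to 30000 nM.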

Compound 4, concentration for 50% growth inhibition: 12900 nM
Beside the measured number, compound 4's estimate is 1.6-fold (0.21 log units) below it, and the stated range covers the measured number.
By their numbers in this assay, from the lowest: compounds 1 and 4 (each within the scatter of the next); then compound 3. At a limit, above all of these: compound 2.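

In this assay, phenyl in place of morpholin-4-yl on a carbonyl carbon gives a 1.0-fold higher number from compound 1 to compound 4 (0.01 log units; within the scatter). This is the first pair among the compounds shown that differs at this one place, and it shows that a non-aromatic ring with hetero atoms and an aromatic ring of carbon only give numbers that cannot be told apart here. Nothing shown accounts for this sameness.

Still open, from the compounds shown here alone, is whether the number would hold with a very different group on this carbonyl carbon, such as a dimethylamino group, a straight alkyl chain or a chain ending in a carboxylic acid. Also open, going by these compounds, is what a change at the other masked place, the benzoyl group on the phenol, would do to the number.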